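Same anilide swap on a second core, fourth value expected

The source may report more compounds than this note shows. Statements on the series, on what has been measured and on what is new or still open speak of the compounds shown alone.

Measured so far:
compound 1 `CC(O)(COc1ccc(S(F)(F)(F)(F)F)cc1)C(=O)Nc1ccc(S(F)(F)(F)(F)F)cc1` — 9800 nM
compound 2 `CC(O)(COc1cccc(S(F)(F)(F)(F)F)c1)C(=O)Nc1ccc(S(F)(F)(F)(F)F)cc1` — 12000 nM
compound 3 `CC(O)(COc1ccc(S(F)(F)(F)(F)F)cc1)C(=O)Nc1ccc(C(F)(F)F)cc1` — 11700 nM

Of the compounds shown here, three have been tested in a functional assay on LNCaP cells (Homo sapiens) for antiproliferative activity, read by propidium iodide staining, with a stated time of 96 h (on this read-out higher numbers stand for weaker inhibition and lower numbers for stronger inhibition), and a fourth awaits its number. Compound 1 and compound 2 share the same atoms joined differently; the difference between the two cores is not broken down here. In this assay compound 1 gives 9800 nM and compound 2 gives 12000 nM, two numbers that sit within the usual scatter of each other, so no order can be read from them.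

Compound 3 carries the core of compound 1 with one change: a group of 4 heavy atoms (1 carbon, 3 fluorine; no ring) in place of a group of 6 heavy atoms (5 fluorine, 1 sulfur; no ring), on an aromatic carbon. The step of a 1.2-fold higher number from compound 1 to compound 3 (0.08 log units; within the scatter) is small and within the scatter.

Compound 4 `CC(O)(COc1cccc(S(F)(F)(F)(F)F)c1)C(=O)Nc1ccc(C(F)(F)F)cc1` is the unmeasured member. Among the measured compounds shown here, it carries the core of compound 2 and differs from it by a group of 4 heavy atoms (1 carbon, 3 fluorine; no ring) in place of a group of 6 heavy atoms (5 fluorine, 1 sulfur; no ring), on an aromatic carbon, which is the same change as the one made from compound 1 to compound 3, at the same kind of place.

For the measured compounds named here, with only one earlier instance to go on, compound 4 is expected to sit near compound 2, with a step of about a 1.2-fold higher number from compound 2 to compound 4 (0.07 log units; within the scatter) that rests on the earlier 1.2-fold higher number from compound 1 to compound 3 (0.08 log units; within the scatter) being within the scatter. The estimate for compound 4 is therefore 14000 nM, with a plausible range from 7000 nM to 30000 nM.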

Compound 4, half-maximal inhibitory concentration: 12800 nM
Estimate against measurement, compound 4: 1.1-fold (0.04 log units) above; the measured number falls inside the stated range.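

In this assay, placing trifluoromethyl on the aromatic carbon that carried the group of 5 fluorine atoms and 1 sulfur atom gives a 1.1-fold higher number from compound 2 to compound 4 (0.03 log units; within the scatter). Set beside the same change on the core of compound 1, the two steps agree, so in these four compounds the change carries from one core to the other without a readable difference between the cores: the same change on two cores in this assay, a 1.2-fold higher number (0.08 log units; within the scatter) from compound 1 to compound 3 and a 1.1-fold higher number (0.03 log units; within the scatter) from compound 2 to compound 4, 1.1-fold (0.05 log units) apart, within the scatter of two such steps

This agreement is a limited one, since neither step stands out from the scatter, and what carries over is the absence of a readable shift rather than a measured effect of a definite size; it does not show how the change would behave on any other core, or that a step beyond the scatter would transfer in the same way.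

The compounds shown leave open whether a nitrile, a chlorine atom, a carboxylic acid or an amine at that same place would move the number beyond the scatter. They also leave open whether altering the shared core itself, for instance by replacing its hydroxyl group or its methyl group or by introducing a longer chain, would do so.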